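The source may hold more compounds than are shown below. What is called first, only, known or untested is meant among the compounds shown, and "the series" means these compounds.

Values in a physicochemical assay for solubility; on this read-out higher numbers stand for higher solubility and lower numbers for lower solubility:
- Compound 1 `CCCNC(=O)c1cc(C(=O)NC)nn1[C@@H](C)c1ccccc1`: >= 132 ug/mL (a limit)
- Compound 2 `CNC(=O)c1cc(C(=O)NC2CCOCC2)n([C@@H](C)c2ccccc2)n1`: 31 ug/mL
- Compound 3 `CNC(=O)c1cc(C(=O)N[C@H]2[C@@H]3COC[C@@H]32)c([C@@H](C)c2ccccc2)o1`: >= 131 ug/mL (a limit)
- Compound 4 `CNC(=O)c1cc(C(=O)N[C@H]2CC[C@H](OC)CC2)c([C@@H](C)c2ccccc2)o1`: not yet measured

Compound 3 stands at >= 131 ug/mL, which is a limit and not a number. The change to compound 4 is a group of 8 heavy atoms (7 carbon, 1 oxygen; one six-membered non-aromatic ring of carbon only) in place of a group of 6 heavy atoms (5 carbon, 1 oxygen; one three-membered non-aromatic ring of carbon only, one five-membered non-aromatic ring with 1 hetero atom), on an amide-type nitrogen, with 4-methoxycyclohexyl entering. Among the compounds with values here, one measured step bears on it, on the same kind of nitrogen but on the core of compound 1: an at least 4.2-fold lower number from compound 1 to compound 2 (0.62 log units; beyond the scatter), with oxan-4-yl in place of propyl. That step starts from a limit. A step of similar size towards a lower number is therefore expected in this assay, estimated as an at least 3.2-fold lower number from compound 3 to compound 4 (0.51 log units; beyond the scatter). The estimate for compound 4 is 40 ug/mL, with an expected range of 12 ug/mL to 130 ug/mL.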

Compound 4, solubility: >= 192 ug/mL
Compound 4: only a limit was reported; the forecaster's own chance of this, stated with the estimate: 15%; at least 4.8-fold (0.68 log units) between middle value and limit.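

In this assay compound 3 and compound 4 are both reported only as limits, so the step between them cannot be read. The compounds shown leave open whether 4-methoxycyclohexyl gives a higher or lower number than the group it replaces.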